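The source may hold more compounds than are shown below. What is called first, only, known or untested is meant among the compounds shown, and "the series" means these compounds.

In a functional assay on PC-3 cells (Homo sapiens) for cytotoxicity, read by MTT assay, with a stated time of 72 h (a higher number here means a weaker inhibitor, a lower number a stronger inhibitor), three compounds that share one core and differ in the phenyl group on the double-bonded chain have been measured. Compound 1 `O=C(/C=C/c1cccc(Cl)c1Cl)Nc1cc2c(Nc3ccc(F)c(Cl)c3)ncnc2cc1O[C@H]1CCOC1` gives 27500 nM, compound 2 `COc1ccc(OC)c(/C=C/C(=O)Nc2cc3c(Nc4ccc(F)c(Cl)c4)ncnc3cc2O[C@H]2CCOC2)c1` gives 8730 nM, and compound 3 `COc1cc(/C=C/C(=O)Nc2cc3c(Nc4ccc(F)c(Cl)c4)ncnc3cc2O[C@H]2CCOC2)cc(OC)c1` gives 25600 nM. That places compound 3 level with compound 1, as a 1.1-fold lower number from compound 1 to compound 3 (0.03 log units; within the scatter) shows, and both stand apart from compound 2, as a 2.9-fold higher number from compound 2 to compound 3 (0.47 log units; beyond the scatter) shows.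

Compound 4 `COc1ccc(/C=C/C(=O)Nc2cc3c(Nc4ccc(F)c(Cl)c4)ncnc3cc2O[C@H]2CCOC2)cc1` differs from compound 3 in one place: 4-methoxyphenyl in place of 3,5-dimethoxyphenyl on a double-bonded chain carbon bound to a double-bonded chain carbon. The change puts 4-methoxyphenyl in place of 3,5-dimethoxyphenyl on a double-bonded chain carbon bound to a double-bonded chain carbon. Going by the values given here, no measured compound carries 4-methoxyphenyl, so no measured step matches this change exactly. The closest guides are the other exchanges of the phenyl group. These were modest at most, with a 3.2-fold lower number from compound 1 to compound 2 (0.50 log units; beyond the scatter) as the largest, and one of them stayed within the scatter. A step of similar or smaller size is therefore expected, leaning towards lower numbers since only compound 2 at 8730 nM departs from the high values. The expected step is a 1.7-fold lower number from compound 3 to compound 4 (0.23 log units; within the scatter). For compound 4 the estimated value is 15000 nM, with an expected range from 6000 nM to 35000 nM.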

Compound 4, half-maximal inhibitory concentration: 2240 nM
Compound 4: middle estimate off by 6.7-fold (0.83 log units), on the high side, and the stated range ends above it.
By their numbers in this assay, from the lowest: compound 4; then compound 2; then compounds 3 and 1 (each within the scatter of the next).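

In this assay, going by these compounds alone, the group on a double-bonded chain carbon can shift the number much further than the earlier exchanges showed: 4-methoxyphenyl gives an 11-fold lower number from compound 3 to compound 4 (1.06 log units; beyond the scatter) and a 12-fold lower number from compound 1 to compound 4 (1.09 log units; beyond the scatter), both large steps, whereas no earlier step went beyond modest. Within the data shown here, it also improves on the one earlier compound that stood apart, with a 3.9-fold lower number from compound 2 to compound 4 (0.59 log units; beyond the scatter), so compound 4 has the lowest number of the four, and neither dimethoxyphenyl group matches the single methoxy group of 4-methoxyphenyl. Nothing at hand bears on why this exchange has so large a step.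

The compounds shown leave open whether the low number depends on the methoxy group itself or would also appear with an unsubstituted phenyl, 4-hydroxyphenyl or 4-ethoxyphenyl in its place. They also leave open whether 3-methoxyphenyl or 2-methoxyphenyl would stay close to compound 4 or return towards the higher numbers of compound 1 and compound 3, which would show how much the place of a single methoxy group on the phenyl ring counts.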